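A few compounds are considered here, and "the series" means these few. Any claim that something is new, unique, unknown or untested is made for them only; others in the source may bear on it.

Compound 1, with the structure `CS(=O)(=O)Oc1c(C(=O)NCc2ccc(F)cc2)nc(Br)c2cccnc12`, is the starting point. In a functional assay on HCT-116 cells (Homo sapiens) for cytotoxicity, read by MTT assay, with a stated time of 72 h (on this read-out lower numbers stand for stronger inhibition and higher numbers for weaker inhibition), compound 1 gives only a limit of the assay, > 20000 nM. Compound 2, with the structure `O=C(NCc1ccc(F)cc1)c1nc(Br)c2cccnc2c1NCc1ccc(F)cc1`, differs from compound 1 by a (4-fluorobenzyl)amino in place of (methylsulfonyl)oxy on an aromatic carbon. In this assay compound 2 likewise gives only a limit, > 20000 nM. The step that the two limits leave unreadable from compound 1 to compound 2 therefore cannot be read, since both values sit at the limit of > 20000 nM in this assay, at which 2 of the 2 values shown sit.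

Compound 3, with the structure `CN(C)CCCNc1c(C(=O)NCc2ccc(F)cc2)nc(Br)c2cccnc12`, carries the change ((3-(dimethylamino)propyl)amino in place of (methylsulfonyl)oxy on an aromatic carbon). Among the measured compounds shown here, the only measured step that bears on this change is the one from compound 1 to compound 2, and its size is not readable, so no expectation of direction or size in this assay can be drawn from it. The two measured compounds share the same core and both sit at the limit, and compound 3 keeps that core. Compound 3 is therefore estimated to give a value of 15000 nM in this assay, with a range from 3000 nM to 40000 nM, which is expected to mean a step of an at least 1.3-fold lower number from compound 1 to compound 3 (0.12 log units; that floor lies within the scatter) from compound 1.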

Compound 3, half-maximal inhibitory concentration: > 10000 nM
Compound 3: a limit, no number (the forecaster's own chance of this, stated with the estimate: 50%); the middle value lies beyond the limit too.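

Compound 3 gives only a limit in this assay, > 10000 nM, so neither the step from compound 1 to compound 3 nor the step from compound 2 to compound 3 can be read. The compounds shown leave open whether (methylsulfonyl)oxy, (4-fluorobenzyl)amino or (3-(dimethylamino)propyl)amino on the shared core differ at all in this read-out.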